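Trading the Chlorophenyl Amide for an Ethoxycarbonyl Group

The source may report more compounds than this note shows. Statements on the series, on what has been measured and on what is new or still open speak of the compounds shown alone.

The measured compounds, with their results in a functional assay on B16 cells (Mus musculus) for inhibition; a lower number here means a stronger inhibitor, a higher number a weaker inhibitor:

compound 1, `COc1cc(/C=C/C(=O)c2cccc(NC(=O)c3c(Cl)cccc3Cl)c2)ccc1O`: 1.58 ug/mL
compound 2, `COc1cc(/C=C/C(=O)c2cccc(NC(=O)c3ccc(Cl)cc3)c2)ccc1O`: 0.59 ug/mL
compound 3, `COC(=O)C(=O)Nc1cccc(C(=O)/C=C/c2ccc(O)c(OC)c2)c1`: 4.41 ug/mL

All three share one core and differ only in the group on the carbonyl carbon attached to the amide-type nitrogen. Compound 2 holds the lowest number of the three in this assay: the steps away from it are a 2.7-fold lower number from compound 1 to compound 2 (0.43 log units; beyond the scatter), read in reverse, and a 7.5-fold higher number from compound 2 to compound 3 (0.87 log units; beyond the scatter), both beyond the scatter. The remaining pair is a 2.8-fold higher number from compound 1 to compound 3 (0.45 log units; beyond the scatter).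

Compound 4, `CCOC(=O)C(=O)Nc1cccc(C(=O)/C=C/c2ccc(O)c(OC)c2)c1`, has not yet been measured. Relative to compound 2 the change is ethoxycarbonyl in place of 4-chlorophenyl on a carbonyl carbon. Going by the values given here, two measured steps bear on it. The closest is a 7.5-fold higher number from compound 2 to compound 3 (0.87 log units; beyond the scatter), where methoxycarbonyl took the same place; ethoxycarbonyl differs from it only by one more carbon in the chain. The step of a 2.8-fold higher number from compound 1 to compound 3 (0.45 log units; beyond the scatter) points the same way. Compound 4 is therefore expected to sit close to compound 3, giving an estimated step of a 6.8-fold higher number from compound 2 to compound 4 (0.83 log units; beyond the scatter) in this assay. For compound 4 the expected value is 4 ug/mL, within a range from 1.5 ug/mL to 10 ug/mL.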

Compound 4, half-maximal inhibitory concentration: 7.03 ug/mL
For compound 4 the middle estimate is 1.8-fold (0.24 log units) below the measured one; low and high end bracket the measured number.
By their numbers in this assay, from the lowest: compound 2; then compound 1; then compounds 3 and 4 (each within the scatter of the next).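

Compound 4 shows that the high number seen with methoxycarbonyl is not confined to that one group: in this assay, ethoxycarbonyl in place of 4-chlorophenyl on this carbonyl carbon gives a 12-fold higher number from compound 2 to compound 4 (1.08 log units; beyond the scatter), a large step, and in place of 2,6-dichlorophenyl it gives a 4.4-fold higher number from compound 1 to compound 4 (0.65 log units; beyond the scatter). Extending methoxycarbonyl to ethoxycarbonyl gives a 1.6-fold higher number from compound 3 to compound 4 (0.20 log units; within the scatter), which lies within the scatter, so the extra methyl makes no difference that can be read in this assay. Across these four compounds, both groups ending in an alkoxy chain therefore stand at higher numbers than both chlorophenyl groups, and none of the four goes against this.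

The compounds shown offer no independent measurement that could account for this separation. Still open, from the compounds shown here alone, is whether a carboxylic acid, a primary amide or a longer chain such as butoxycarbonyl would stay with compounds 3 and 4 at this carbonyl carbon, and whether an unsubstituted phenyl would come closer to the number of compound 2.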